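This account rests on a few compounds, and the source may have more. Where it says the series, first, only, none or still open, it means among the compounds named here.

Of the compounds shown here, three from this series have been measured in a functional assay on HL-60 cells (Homo sapiens) for inhibition, read by MTT assay, with a stated time of 48 h, tested at 10 uM; on this read-out lower numbers stand for less inhibition of growth and higher numbers for more inhibition of growth at the one concentration tested. Compound 1 `O=C(N/N=C/c1ccccc1O)c1ccc(-c2ccc(F)cc2)o1` gives 13.1% in this assay. Compound 2 `O=C(N/N=C/c1ccccc1)c1ccc(-c2ccc(Cl)cc2)o1` gives 25.8% in this assay, and compound 3 `Cc1cccc(/C=N/NC(=O)c2ccc(-c3ccccc3[N+](=O)[O-])o2)c1` gives 9.54% in this assay. Among these three numbers compound 1 stands second highest; its nearest neighbour is compound 3, whose number lies within the usual scatter of compound 1, while compound 2 lies furthest away, with a number higher than that of compound 1 by more than the scatter.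

Compound 4 `O=C(N/N=C/c1ccccc1Cl)c1ccc(-c2ccc(F)cc2)o1` has not yet been measured. It differs from compound 1 in one place: chloro in place of hydroxy on an aromatic carbon. Among the compounds with values here, no pair of measured compounds in this set differs in exactly one place, so no measured step can be read off for guidance. Within the data shown here, because the only values at hand are 13.1% for compound 1 and 25.8% for compound 2, and neither isolates this change, the expectation for compound 4 rests on the whole spread of the three numbers, which is narrow. The step from compound 1 to compound 4 is therefore expected to be small, a number 3.9 percentage points higher from compound 1 to compound 4 (within the scatter), and to stay within the scatter, with no clear direction. On this basis compound 4 is estimated to give 17% in this assay, with a plausible range from 5% to 32%.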

Compound 4, percent growth inhibition at one concentration: -3.22%
For compound 4 the middle estimate is 20.2 percentage points above the measured one, and the stated range ends above it.
By their numbers in this assay, from the lowest: compound 4; then compounds 3 and 1 (each within the scatter of the next); then compound 2.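

Within the data shown here, the first step in this set that isolates a single place concerns the change from 2-hydroxyphenyl to 2-chlorophenyl, ortho to a large group: in this assay it gives a number 16.3 percentage points lower from compound 1 to compound 4 (beyond the scatter). This shows that the group at this position is not a matter of indifference, since swapping one heavy atom here moves the read-out beyond the scatter, and compound 4 gives -3.22%, so at the one concentration tested the chloro compound shows no growth inhibition. The change also takes away the hydrogen-bond donor and hydrogen-bond acceptor counted for hydroxy, but no measurement at hand ties the drop to this or to any other feature.

The compounds shown leave open how a methoxy group, an amine or a plain hydrogen at this same place would compare with hydroxy and chloro, and so whether hydroxy raises the number or chloro lowers it. They also leave open whether the same exchange would give a step of similar size with a different group elsewhere on the core.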